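Phenyl for Cyclohexyl on the Ester Chain

The source may hold more compounds than are shown below. What is called first, only, known or untested is meant among the compounds shown, and "the series" means these compounds.

Measured compounds:
compound 1, `CCCOC(=O)[C@@]12C[C@@H]1[C@@H](n1cnc3c(NC)nc(C#Cc4ccc(Cl)s4)nc31)[C@H](O)[C@@H]2O`: 5.78 nM
compound 2, `CNc1nc(C#Cc2ccc(Cl)s2)nc2c1ncn2[C@H]1[C@H](O)[C@H](O)[C@]2(C(=O)OC(C)C)C[C@H]12`: 42.9 nM
compound 3, `CNc1nc(C#Cc2ccc(Cl)s2)nc2c1ncn2[C@H]1[C@H](O)[C@H](O)[C@]2(C(=O)OCCC3CCCCC3)C[C@H]12`: 770 nM

These three compounds share one core and differ only in the group on the ester oxygen, and all were tested in an assay on HEK-293T cells for displacement of a labelled ligand from transmembrane domain-containing protein TMIGD3 (Homo sapiens), read by scintillation counting and radioligand binding, with stated times of 10 min and 90 min; a lower number here means a stronger inhibitor, a higher number a weaker inhibitor. Among them compound 3 stands at the highest number: compound 2 is its nearest neighbour, a step of an 18-fold higher number from compound 2 to compound 3 (1.25 log units; beyond the scatter), and compound 1 the furthest, a step of a 130-fold higher number from compound 1 to compound 3 (2.12 log units; beyond the scatter). The smaller change between the two lower numbers is a 7.4-fold higher number from compound 1 to compound 2 (0.87 log units; beyond the scatter).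

Compound 4, `CNc1nc(C#Cc2ccc(Cl)s2)nc2c1ncn2[C@H]1[C@H](O)[C@H](O)[C@]2(C(=O)OCCc3ccccc3)C[C@H]12`, differs from compound 3 by phenyl in place of cyclohexyl on a saturated chain carbon, two bonds along the chain from an oxygen next to a carbonyl group; cut one bond further out, the change reads 2-cyclohexylethyl to phenethyl. Among the measured compounds shown here, none of the measured steps swaps a saturated ring for an aromatic one, so no step bears on this change directly. The measured steps all go from a smaller ester group to a larger one, and compound 3 already carries the largest. Compound 4 keeps the same chain length and ring size, so the step of a 1.5-fold lower number from compound 3 to compound 4 (0.19 log units; within the scatter) is expected to stay within the scatter. Compound 4 is therefore estimated at 500 nM, in the range 150 nM to 2000 nM.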

Compound 4, inhibition constant: 262 nM
Compound 4: middle estimate off by 1.9-fold (0.28 log units), on the high side; low and high end bracket the measured number.
By their numbers in this assay, from the lowest: compound 1; then compound 2; then compound 4; then compound 3.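

Among the compounds shown here, at this position the kind of ring matters as well as the size of the ester group: with phenyl in place of cyclohexyl on the same chain, there is a 2.9-fold lower number from compound 3 to compound 4 (0.47 log units; beyond the scatter), a step beyond the scatter that the earlier compounds, none of which has an aromatic ring on the ester chain, could not reveal. The phenyl ring recovers only part of the ground lost with the larger ester group, since there remains a 6.1-fold higher number from compound 2 to compound 4 (0.79 log units; beyond the scatter) and, against the propyl ester, a 45-fold higher number from compound 1 to compound 4 (1.66 log units; beyond the scatter). Nothing available here accounts for the difference between the two rings.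

The compounds shown leave open whether a pyridine ring on the same chain would behave like phenyl, and whether phenyl keeps its edge over cyclohexyl on a longer chain. They also leave open how a methyl or ethyl ester compares with the propyl ester.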